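This account rests on a few compounds, and the source may have more. Where it says the series, first, only, none or still open, it means among the compounds named here.

Three compounds sharing one core have been examined in a functional assay on MDA-MB-435 cells (Homo sapiens) for inhibition; on this read-out higher numbers stand for weaker inhibition of growth and lower numbers for stronger inhibition of growth. Compound 1 `COc1cc(/C=C/C(=O)c2cccc(-n3cc(-c4ccc(Cl)cc4)[nH]c3=O)c2)cc(OC)c1OC` gives 3630 nM in this assay. Compound 2 `COc1cc(/C=C/C(=O)c2cccc(-n3cc(-c4ccccc4)[nH]c3=O)c2)ccc1O` gives 2140 nM in this assay, and compound 3 `O=C(/C=C/c1cccc(O)c1)c1cccc(-n2cc(-c3ccc(Cl)cc3)[nH]c2=O)c1` gives 2060 nM. For the measured compounds named here, of these three numbers, the one for compound 1 is the highest, yet its gaps to compound 2 and to compound 3 both lie within the usual scatter of repeated measurements, so on these values the three compounds cannot be told apart.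

Compound 4 `COc1ccc(-c2cn(-c3cccc(C(=O)/C=C/c4cc(OC)c(OC)c(OC)c4)c3)c(=O)[nH]2)cc1` has not yet been measured. It differs from compound 1 in one place: methoxy in place of chloro on an aromatic carbon. Elsewhere the two structures are the same. Going by the values given here, no measured pair in this set carries the same change, so there is no direct precedent for what it does in this assay. Because the three measured values of compounds 1, 2 and 3 sit so close together, the expectation is a small step, a 1.4-fold lower number from compound 1 to compound 4 (0.14 log units; within the scatter), with no clear direction beyond the scatter. On that basis compound 4 is expected to give about 2600 nM in this assay, with a range from 900 nM to 7500 nM.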

Compound 4, concentration for 50% growth inhibition: 1860 nM
For compound 4 the middle estimate is 1.4-fold (0.15 log units) above the measured one; the measured number falls inside the stated range.
By their numbers in this assay, from the lowest: compounds 4, 3, 2 and 1 (each within the scatter of the next).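

In this assay, for the compounds shown here, this is the first pair in the set that differs in one place only, and putting methoxy in place of chloro, para to a large group on the six-membered aromatic ring, gives a 2.0-fold lower number from compound 1 to compound 4 (0.29 log units; within the scatter). So this position can carry either group, one adding a heavy atom and a hydrogen-bond acceptor that the other lacks, and the read-out still does not separate the 4-chlorophenyl from the 4-methoxyphenyl compound: the step does not go beyond what repeated measurements of one compound would show. No measurement shown here offers a reason for this result, and one pair cannot show whether the two groups truly match or differ by a small amount hidden in the scatter.

From the compounds shown here alone, whether the position stays this undemanding with a different kind of group, such as an amine or a carboxylic acid in the same place, remains open. Also open, going by these compounds, is whether the same exchange of chloro for methoxy would read the same way on a compound with a different other end, such as compound 3, whose other aromatic ring carries a single hydroxyl group.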